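The source may report more compounds than this note shows. Statements on the series, on what has been measured and on what is new or still open speak of the compounds shown alone.

Measured in a functional assay on LNCaP cells (Homo sapiens) for antiproliferative activity; a lower number here means a stronger inhibitor, a higher number a weaker inhibitor:
- compound 1 `Cn1ncc(Cl)c1-c1cc(C(=O)N[C@@H]2CN[C@H](CC(O)CO)C[C@H]2c2ccc(F)c(F)c2)oc1Cl`: 100 nM
- compound 2 `Cn1ncc(Cl)c1-c1cc(C(=O)N[C@@H]2CN[C@H](CCn3cncn3)C[C@H]2c2ccc(Cl)c(Cl)c2)oc1Cl`: 60 nM
- compound 3 `CC(=O)NCC[C@@H]1C[C@@H](c2ccc(F)c(F)c2)[C@H](NC(=O)c2cc(-c3c(Cl)cnn3C)c(Cl)o2)CN1`: 130 nM

In this assay, compound 2 at 60 nM lies within the scatter of compound 1, while its gap to compound 3 lies beyond the scatter. Compound 4 `C=CC[C@@H]1C[C@@H](c2ccc(Cl)c(Cl)c2)[C@H](NC(=O)c2cc(-c3c(Cl)cnn3C)c(Cl)o2)CN1` has vinyl in place of (1H-1,2,4-triazol-1-yl)methyl on a saturated chain carbon bound to a saturated ring carbon. One measured step alters that same place, a 1.3-fold higher number from compound 1 to compound 3 (0.11 log units; within the scatter), and it stays within the scatter. For the measured compounds named here, no measured compound carries vinyl there, so this evidence is thin, and no step beyond the scatter is expected in either direction. The expected step is a 1.3-fold higher number from compound 2 to compound 4 (0.12 log units; within the scatter). For compound 4 the estimated value is 80 nM, with an expected range of 25 nM to 250 nM.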

Compound 4, half-maximal inhibitory concentration: 160 nM
Compound 4: the middle estimate sits 2.0-fold (0.30 log units) below what was measured; low and high end bracket the measured number.
By their numbers in this assay, from the lowest: compounds 2, 1, 3 and 4 (each within the scatter of the next, the first and the last beyond it).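

In this assay, replacing 2-(1H-1,2,4-triazol-1-yl)ethyl with allyl gives a 2.7-fold higher number from compound 2 to compound 4 (0.43 log units; beyond the scatter). For the compounds shown here, this is the first step beyond the scatter at this place, since the earlier change there, a 1.3-fold higher number from compound 1 to compound 3 (0.11 log units; within the scatter), stayed within it, so this position does not tolerate every side chain equally. Nothing available explains this step. The compounds shown leave open whether the triazole ring itself matters or a simple propyl chain or a 2-aminoethyl group would serve as well.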